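A few compounds are considered here, and "the series" means these few. Any claim that something is new, unique, unknown or untested is made for them only; others in the source may bear on it.

- compound 1 `Cn1c(COc2cccc(C(=O)O)c2)nc2ccc(Oc3ccc4c(c3)OCC4)nc21`: 9.1 10^-6 cm/s
- compound 2 `Cc1ccnc(Oc2ccc3nc(COc4cccc(C(=O)O)c4)n(C)c3c2)c1`: 3.5 10^-6 cm/s

Both values come from an ADME assay for permeability, using PAMPA, with a stated time of 4 h; on this read-out lower numbers stand for lower permeability and higher numbers for higher permeability. Of these two measurements, compound 2 stands lowest at 3.5 10^-6 cm/s, and compound 1 gives 9.1 10^-6 cm/s, a gap that lies beyond the scatter. These two compounds differ in more than one place, so their values give no clean reading of any single change.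

The next compound is compound 3 `Cn1c(COc2cccc(C(=O)O)c2)nc2ccc(Oc3ncc(Cl)cc3Cl)cc21`, whose difference from compound 2 is 3,5-dichloropyridin-2-yl in place of 4-methylpyridin-2-yl on an oxygen on an aromatic ring. In words, 3,5-dichloropyridin-2-yl takes the place of 4-methylpyridin-2-yl on an oxygen on an aromatic ring. Among the compounds with values here, no measured pair shows this change, so the expectation in this assay is tentative. A small upward move is expected, not beyond the scatter, and the estimated step is a 1.7-fold higher number from compound 2 to compound 3 (0.23 log units; within the scatter). For compound 3 the expected value is 6 10^-6 cm/s, with an estimated range of 2.5 10^-6 cm/s to 14 10^-6 cm/s.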

Compound 3, apparent permeability: 16.1 10^-6 cm/s
Beside the measured number, compound 3's estimate is 2.7-fold (0.43 log units) below it; the measured number lies above the stated range.
By their numbers in this assay, from the lowest: compound 2; then compounds 1 and 3 (each within the scatter of the next).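

In this assay, the group on an oxygen on an aromatic ring now has its first reading from a pair that differs in one place: 3,5-dichloropyridin-2-yl in place of 4-methylpyridin-2-yl gives a 4.6-fold higher number from compound 2 to compound 3 (0.66 log units; beyond the scatter) and so moves the read-out past the usual scatter. This shows that the read-out responds to a change at this position, though the evidence is a single pair, and the swap changes the ring's substituents from one methyl to two chlorines. Nothing available explains the origin of this step.

The pair cannot separate the loss of the methyl from the gain of either chlorine, so a group such as 3-chloropyridin-2-yl or 5-chloropyridin-2-yl would be needed to assign the step. As far as these compounds go, whether an amine or a methoxy group at this position would move the number in the same direction remains open.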